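Fluoro in place of chloro: cytotoxicity in human astrocytes

The compounds below may be only part of what the source reports. "The series", "measured", "known", "first", "only" and "open" are said of these compounds alone.

Compound 1, `O=C(Nc1cccc(Cl)c1)Nc1cc2ncncc2cc1OCc1ccccc1Cl`, in an ADME assay on cells (Astrocyte, Homo sapiens) for cytotoxicity, read by WST assay, with a stated time of 72 h; on this read-out higher numbers stand for weaker inhibition and lower numbers for stronger inhibition: > 10000 nM, which is a limit of the assay and not a number.
Compound 2, `O=C(Nc1cc2ncncc2cc1OCc1ccc(Cl)cc1)Nc1cccc2ccccc12`, in this assay: > 10000 nM, again a limit of the assay and not a number.
Compound 3, `O=C(Nc1cc2ncncc2cc1OCc1ccc(F)cc1)Nc1cccc2ccccc12`, in this assay: 8500 nM.

Two of the three measured compounds sit at the same limit, as the limit of > 10000 nM in this assay, at which 2 of the 3 values shown sit, records, so only compound 3 returns an actual number. Within the data shown here, the one measured step is the change from compound 2 to compound 3, (fluoro in place of chloro on an aromatic carbon), which gave an at least 1.1-fold lower number from compound 2 to compound 3 (0.07 log units; that floor lies within the scatter). How the cores of compound 1 and compound 2 differ is not broken down here.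

Compound 4, `O=C(Nc1cccc(F)c1)Nc1cc2ncncc2cc1OCc1ccccc1Cl`, has not yet been measured. It differs from compound 1 by fluoro in place of chloro on an aromatic carbon. This is the same kind of change as the measured one, but not the same: in compound 4 the new fluoro sits meta to a large group, whereas in compound 3 it sits para to a large group.

Given that the measured step of an at least 1.1-fold lower number from compound 2 to compound 3 (0.07 log units; that floor lies within the scatter) moved a limit only into a value close to it, the step from compound 1 to compound 4 in this assay is expected to be a number no higher from compound 1 to compound 4 (the limit leaves the size open). Compound 4 is therefore estimated at 10000 nM, most likely between 5500 nM and 20000 nM, with a real chance that the assay again reports only a limit.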

Compound 4, half-maximal inhibitory concentration: 9400 nM
Estimate against measurement, compound 4: 1.1-fold (0.03 log units) above, within the range that was stated.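

In this assay, fluoro in place of chloro, here 3-chlorophenyl to 3-fluorophenyl, gives an at least 1.0-fold lower number from compound 1 to compound 4 (0.02 log units; that floor lies within the scatter), and this is the second core on which the change leads from a limit to an actual number. Set side by side, the two steps point the same way as far as they can be read, but they cannot be told apart: the same change on two cores in this assay, an at least 1.1-fold lower number (0.07 log units; that floor lies within the scatter) from compound 2 to compound 3 and an at least 1.0-fold lower number (0.02 log units; that floor lies within the scatter) from compound 1 to compound 4; the limit leaves it open whether they differ What this does not show is the true size of either step, or that the change carries from one core to another with the same size, since each step starts from a compound that returns no actual number: the limit of > 10000 nM in this assay, at which 2 of the 4 values shown sit.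

The compounds shown leave open how other groups on the same aromatic carbon, such as a methoxy group, an amine or a carboxylic acid, would read in this assay. They also leave open what the same swap of chloro for fluoro would do when the starting compound gives a real number, which is the only case in which the size of the step could be read directly and compared between cores.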